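The source may hold more compounds than are shown below. What is called first, only, known or untested is meant among the compounds shown, and "the series" means these compounds.

Compound 1 `O=C(Cc1cccnc1)c1cc2ccccc2[nH]1` holds the higher of the two numbers recorded so far in an assay on isolated protein for inhibition of Indoleamine 2,3-dioxygenase 1 (Homo sapiens), read by spectrophotometry; a higher number here means a weaker inhibitor, a lower number a stronger inhibitor: compound 1 gives 65000 nM. Compound 2 `O=C(Cc1cnccn1)c1cc2ccccc2[nH]1` gives 26200 nM, and the step of a 2.5-fold lower number from compound 1 to compound 2 (0.39 log units; beyond the scatter) is a modest one. Compound 3 `O=C(Cc1cccnc1)c1cc2cc(Br)ccc2[nH]1` differs from compound 1 only by bromo in place of hydrogen on an aromatic carbon. Among the measured compounds shown here, that change sits on a part of the shared core that the one measured step leaves untouched, so no recorded step speaks to it directly. Compound 3 is therefore expected to stay close to compound 1, with the step of a 1.4-fold lower number from compound 1 to compound 3 (0.16 log units; within the scatter) not expected to exceed the scatter. Compound 3 is estimated at 45000 nM, within a range from 15000 nM to 130000 nM.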

Compound 3, half-maximal inhibitory concentration: 18000 nM
Estimate against measurement, compound 3: 2.5-fold (0.40 log units) above; low and high end bracket the measured number.
By their numbers in this assay, from the lowest: compounds 3 and 2 (each within the scatter of the next); then compound 1.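

In this assay, bromo in place of hydrogen on an aromatic carbon gives a 3.6-fold lower number from compound 1 to compound 3 (0.56 log units; beyond the scatter) and so shows that this part of the shared core, untouched by the earlier step, also affects the number. The drop is modest but lies beyond the scatter. Nothing measured here bears on its cause.

From the compounds shown here alone, whether chloro or methoxy on this same carbon would give a similar drop remains open. So does whether bromo would lower the number further when combined with the pyrazin-2-yl group of compound 2.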